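Carbamoyl to carboxy: a well-tolerated compound changed

The source may report more compounds than this note shows. Statements on the series, on what has been measured and on what is new or still open speak of the compounds shown alone.

Measured in a toxicity assay on CCRF-CEM cells (Homo sapiens) for cytotoxicity; a lower number here means that less compound is tolerated, a higher number that more compound is tolerated:
Compound 1 `CCc1cccc2c1nc(-c1c(F)cccc1F)n2Cc1c(F)cccc1F`: 26.1 uM
Compound 2 `NC(=O)c1cccc2c1nc(-c1c(F)cccc1F)n2Cc1c(F)cccc1F`: > 100 uM (a limit of the assay)

Compound 2 stands only at a limit, > 100 uM. Compound 3 `O=C(O)c1cccc2c1nc(-c1c(F)cccc1F)n2Cc1c(F)cccc1F` differs from it by hydroxy in place of amino on a carbonyl carbon, with hydroxy in place of amino on a carbonyl carbon. Among the measured compounds shown here, the single measured step, an at least 3.8-fold higher number from compound 1 to compound 2 (0.58 log units; beyond the scatter), brought in carbamoyl in place of ethyl. It is a different change and ends at a limit, so it gives no firm size here. No step beyond the scatter is expected, in either direction. The expected step is a number no higher from compound 2 to compound 3 (the limit leaves the size open). Compound 3 is estimated at 100 uM, with an expected range from 45 uM to 220 uM.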

Compound 3, half-maximal toxic concentration: 23.5 uM
Compound 3: the middle estimate sits 4.3-fold (0.63 log units) above what was measured; the measured number lies below the stated range.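

In this assay, one atom changed on the carbonyl carbon is enough to move the result: hydroxy in place of amino gives an at least 4.2-fold lower number from compound 2 to compound 3 (0.62 log units; beyond the scatter). The high tolerated concentration therefore does not hold for every carbonyl group at this position, and carboxy in place of ethyl gives only a 1.1-fold lower number from compound 1 to compound 3 (0.05 log units; within the scatter). Compound 2 stands at a limit of the assay, so the full size of its step stays unknown: the limit of > 100 uM in this assay, at which 1 of the 3 values shown sits.

Going by these compounds, it remains open whether a methyl amide or a methyl ester would follow carbamoyl or carboxy here.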